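The compounds below may be only part of what the source reports. "The series", "measured", "known", "first", "only" and "open" are said of these compounds alone.

Compound 1 `O=c1cc(-c2ccccc2)oc2cccc(OCCCN3CCC(O)CC3)c12` is the reference point here. In an assay on isolated protein (Cavia porcellus) with Sigma non-opioid intracellular receptor 1 (Homo sapiens) as the target, read by radioligand binding (on this read-out lower numbers stand for stronger inhibition and higher numbers for weaker inhibition), compound 1 gives 91 nM. Compound 2 `O=c1cc(-c2ccccc2)oc2cccc(OCCCCN3CCC(O)CC3)c12` carries (4-hydroxypiperidin-1-yl)methyl in place of 4-hydroxypiperidin-1-yl on a saturated chain carbon, three bonds along the chain from an oxygen on an aromatic ring and in this assay compound 2 gives 177 nM; the resulting step is a 1.9-fold higher number from compound 1 to compound 2 (0.29 log units; within the scatter). Compound 3 `COc1ccc(-c2cc(=O)c3cc(OCCCCCN4CCC(O)CC4)ccc3o2)cc1` belongs to a second core, and the difference between the two cores is not broken down here; in this assay compound 3 gives 600 nM, the highest of the three numbers and beyond the scatter from both compound 1 and compound 2.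

Compound 4 `COc1ccc(-c2cc(=O)c3cc(OCCCCCCN4CCC(O)CC4)ccc3o2)cc1` has not yet been measured. Relative to compound 3 it carries (4-hydroxypiperidin-1-yl)methyl in place of 4-hydroxypiperidin-1-yl on a saturated chain carbon, five bonds along the chain from an oxygen on an aromatic ring. Going by the values given here, this is the same kind of change as the one from compound 1 to compound 2, though not the same: there the place was three bonds along the chain from an oxygen on an aromatic ring, here it is five bonds along the chain. On the second core, the expected step is a 1.7-fold higher number from compound 3 to compound 4 (0.22 log units; within the scatter), resting on the earlier step of a 1.9-fold higher number from compound 1 to compound 2 (0.29 log units; within the scatter) and on compound 3 already standing at 600 nM. Compound 4 is therefore estimated at 1000 nM, expected to fall between 400 nM and 2500 nM.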

Compound 4, half-maximal inhibitory concentration: 332 nM
Compound 4: the middle estimate sits 3.0-fold (0.48 log units) above what was measured, outside the stated range (below it).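

In this assay, (4-hydroxypiperidin-1-yl)methyl in place of 4-hydroxypiperidin-1-yl on the second core gives a 1.8-fold lower number from compound 3 to compound 4 (0.26 log units; within the scatter), and set beside the earlier step, the change does not carry over as the same step from one core to the other: the same change on two cores in this assay, a 1.9-fold higher number (0.29 log units; within the scatter) from compound 1 to compound 2 and a 1.8-fold lower number (0.26 log units; within the scatter) from compound 3 to compound 4, 3.5-fold (0.55 log units) apart, beyond the scatter of two such steps. This shows that, in this series, the step on the core of compound 1 did not serve as a reliable guide to the step on the second core. It does not show a rule for either core, since each step rests on a single pair and is within the scatter on its own, and the two pairs differ in the place of the change as well as in the core, three bonds along the chain in one and five bonds in the other.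

From the compounds shown here alone, it remains open how the two cores would compare with the same chain attached, and whether a longer chain would follow either step. Also open, going by these compounds, is whether an open-chain amine in place of the 4-hydroxypiperidin-1-yl group would behave alike on both cores.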